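The source may hold more compounds than are shown below. What is called first, only, known or untested is meant among the compounds shown, and "the series" means these compounds.

Compound 1 `O=c1c2ccccc2[se]n1-c1nnc(-c2cccc([N+](=O)[O-])c2)s1` — 27300 nM
Compound 2 `O=c1c2ccccc2[se]n1-c1nnc(-c2cc([N+](=O)[O-])cc([N+](=O)[O-])c2)s1` — 21600 nM
Compound 3 `COc1ccccc1-c1nnc(-n2[se]c3ccccc3c2=O)s1` — 14300 nM

In a functional assay on SSMC-7721 cells (Homo sapiens) for antiproliferative activity, read by CCK-8 assay, with a stated time of 48 h (on this read-out lower numbers stand for stronger inhibition and higher numbers for weaker inhibition), compound 1 stands at the highest of the three numbers, yet neither neighbour is separated from it by more than the scatter: the step of a 1.3-fold lower number from compound 1 to compound 2 (0.10 log units; within the scatter) lies within it, and compound 3 is likewise within the scatter of compound 1. Compound 4 `Cc1cccc(-c2nnc(-n3[se]c4ccccc4c3=O)s2)c1` differs from compound 1 by methyl in place of nitro on an aromatic carbon. Among the compounds with values here, no measured step exchanges nitro for methyl. Within the data shown here, the only step in hand, a 1.3-fold lower number from compound 1 to compound 2 (0.10 log units; within the scatter), added a nitro and changed nothing beyond the scatter, and compound 3, which carries methoxy where compound 1 carries nitro, also sits within the scatter. Compound 4 is therefore expected to move by a 1.4-fold lower number from compound 1 to compound 4 (0.16 log units; within the scatter), no more than the scatter. Compound 4 is estimated at 19000 nM, within 8000 nM to 45000 nM.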

Compound 4, half-maximal inhibitory concentration: 17800 nM
Compound 4: middle estimate off by 1.1-fold (0.03 log units), on the high side, within the range that was stated.
By their numbers in this assay, from the lowest: compounds 3, 4, 2 and 1 (each within the scatter of the next).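

In this assay, exchanging nitro for methyl at this place on the six-membered aromatic ring gives a 1.5-fold lower number from compound 1 to compound 4 (0.19 log units; within the scatter) and so stays within the scatter. Within the data shown here, this is the first direct exchange at this place, and it shows that a group with two hydrogen-bond acceptors and one with none can stand here without a difference that can be read. Compounds 1 and 4 thus share this level despite the exchange of three heavy atoms for one.

From the compounds shown here alone, whether an amine or a carboxylic acid at this place would move the number beyond the scatter remains open. So does whether a longer chain such as propyl would do so. Nothing available explains why this exchange stays within the scatter.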